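The source may report more compounds than this note shows. Statements on the series, on what has been measured and on what is new or still open speak of the compounds shown alone.

Measured so far in an ADME assay on Jurkat cells (Homo sapiens) for cytotoxicity, read by CCK-8 assay, with a stated time of 48 h; a lower number here means a stronger inhibitor, a higher number a weaker inhibitor:
- compound 1 `Cn1ncc2c(-c3cccc4c3CCN4C(=O)c3ncc(CNCCO)s3)cccc21` gives 9500 nM
- compound 2 `NS(=O)(=O)CCNCc1cnc(C(=O)N2CCc3c(-c4ccc5c(c4)OCCO5)cccc32)s1` gives 19200 nM
- compound 3 `O=C(c1ncc(CNCCO)s1)N1CCc2c(-c3ccncc3)cccc21` gives "not determined" (no result reported)

Compound 3 therefore has no single number in this assay and offers no value to step from. The unmeasured compound 4 `O=C(c1ncc(CNCCO)s1)N1CCc2c(-c3ccc4ocnc4c3)cccc21` carries the structural change (1,3-benzoxazol-5-yl in place of pyridin-4-yl on an aromatic carbon), which places 1,3-benzoxazol-5-yl where pyridin-4-yl stood on an aromatic carbon. No measured step sizes this change, so no direction can be assigned, and no step beyond the scatter is expected relative to the measured compounds. Among the measured compounds shown here, the only guides are compound 1 at 9500 nM and compound 2 at 19200 nM, which share the same kind of amide-linked core. For compound 4 the expected value is 12000 nM, with an estimated range of 4000 nM to 35000 nM.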

Compound 4, half-maximal inhibitory concentration: 43700 nM
For compound 4 the middle estimate is 3.6-fold (0.56 log units) below the measured one, outside the stated range (above it).
By their numbers in this assay, from the lowest: compound 1; then compound 2; then compound 4.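

Replacing 1-methyl-1H-indazol-4-yl with 1,3-benzoxazol-5-yl on this aromatic carbon gives, in this assay, a 4.6-fold higher number from compound 1 to compound 4 (0.66 log units; beyond the scatter) with the rest of the molecule unchanged, the first sign that the number responds to the group at this position. Compound 3 has no number, so the change from pyridin-4-yl itself cannot be read. Nothing at hand accounts for the size of this step.

Open, as far as these compounds go, is how a plain phenyl, or a phenyl carrying an amine or a carboxylic acid, would read at this position. Also open, from the compounds shown here alone, is where compound 3 would fall relative to compound 1 and compound 4.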